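The compounds below may be only part of what the source reports. "The series", "measured", "known", "first", "only" and "open" are said of these compounds alone.

Measured so far in an ADME assay on Vero cells (Chlorocebus sabaeus) for cytotoxicity; a higher number here means that more compound is tolerated, a lower number that less compound is tolerated:
compound 1 `CCCc1cc(-c2cn([C@H]3C[C@H](OC(C)=O)[C@@H](COC(C)=O)O3)c(=O)[nH]c2=O)on1` — 3000 nM
compound 2 `CCCCCc1cc(-c2cn([C@H]3C[C@H](OC(C)=O)[C@@H](COC(C)=O)O3)c(=O)[nH]c2=O)on1` — 3000 nM
compound 3 `CC(C)(C)c1ccc(-c2cc(-c3cn([C@H]4C[C@H](O)[C@@H](CO)O4)c(=O)[nH]c3=O)on2)cc1` — 3000 nM

Compound 2 stands level with compound 1 and compound 3 in this assay, all three values within the scatter of one another. Compound 4 `CC(=O)OC[C@H]1O[C@@H](n2cc(-c3cc(-c4ccc(C(C)C)cc4)no3)c(=O)[nH]c2=O)C[C@@H]1OC(C)=O` differs from compound 2 in one place: 4-isopropylphenyl in place of pentyl on an aromatic carbon. Among the measured compounds shown here, the only step measured, no change at the digits printed from compound 1 to compound 2 (within the scatter), is a change of a different kind and shows no movement. Compound 3 carries an aryl group on the shared core and gives 3000 nM, but it differs from compound 2 in more than one place, so it bears only loosely on the present step. Nothing here points to a shift beyond the scatter; the step of no change at the digits printed from compound 2 to compound 4 (within the scatter) is expected to be flat. Compound 4 is therefore estimated at 3000 nM, between 1500 nM and 6000 nM.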

Compound 4, half-maximal cytotoxic concentration: 3000 nM
For compound 4 middle estimate and measured number coincide at the digits printed; the range from low to high includes it.
By their numbers in this assay, from the lowest: compounds 1, 2, 3 and 4 (each within the scatter of the next).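

In this assay, the aromatic carbon next to the ring nitrogen shows no change at the digits printed from compound 2 to compound 4 (within the scatter) with 4-isopropylphenyl in place of pentyl, and no change at the digits printed from compound 1 to compound 4 (within the scatter) with 4-isopropylphenyl in place of propyl. Among the compounds carrying the two acetate groups, the position therefore gives the same reading with a six-membered aromatic ring of carbon only as with either alkyl chain, whereas the earlier step covered only a longer chain. No supporting data explain this flat reading. Going by these compounds, whether an amine or a carboxylic acid at this position would shift the reading remains open.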